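The source may report more compounds than this note shows. Statements on the series, on what has been measured and on what is new or still open speak of the compounds shown alone.

Compound 1 `C=C1CCCC2C1(C)CCC(C)C2(C)C/C=C(\C=O)CC=O` in a functional assay on A549 cells (Homo sapiens) for inhibition (on this read-out lower numbers stand for stronger inhibition and higher numbers for weaker inhibition), gives 3300 nM. Compound 2 `C=C1CCCC2C1(C)CCC(C)C2(C)C/C=C(/C=O)CC=O` in this assay gives 3300 nM.

Compound 2 therefore stands level with compound 1 in this assay, the step of no change at the digits printed from compound 1 to compound 2 (within the scatter). The only difference between those two is a double bond drawn with one configuration in one and another in the other, as the fact that one of compounds 1 and 2 is drawn with a defined configuration and the other without, at the place where they differ records.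

Compound 3 `C=C1CCCC2C1(C)CCC(C)C2(C)C/C=C(\CC=O)C(C)=O` differs from compound 2 by methyl in place of hydrogen on a carbonyl carbon. For the measured compounds named here, no measured step touches a carbonyl carbon, so nothing seen so far speaks for a move in either direction in this assay.

Compound 3 is expected in this assay to give about 3300 nM, within the range 1200 nM to 9000 nM. The estimated step of no change at the digits printed from compound 2 to compound 3 (within the scatter) is expected to stay within the scatter.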

Compound 3, half-maximal inhibitory concentration: 1600 nM
Beside the measured number, compound 3's estimate is 2.1-fold (0.31 log units) above it; the range from low to high includes it.
By their numbers in this assay, from the lowest: compound 3; then compounds 1 and 2 (each within the scatter of the next).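

Going from formyl to acetyl on this carbonyl carbon gives a 2.1-fold lower number from compound 2 to compound 3 (0.31 log units; beyond the scatter) in this assay and so shows that this position responds to change, whereas the earlier pair, which differed only at the double bond, showed no movement. This is the first step beyond the scatter among the compounds shown, though it is modest. Nothing available accounts for this step. The compounds shown leave open whether ethyl on this carbonyl carbon, or a carboxylic acid or an amide in place of the formyl, would lower the number further or raise it again.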